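The compounds below may be only part of what the source reports. "The series", "measured", "known", "first", "only" and "open" are said of these compounds alone.

Among the compounds with values here, compound 3 `O=C1C=CC(=O)C(c2cc(-c3ccc(Cl)cc3)nn2-c2ccccc2)=C1` gives the highest number of the three compounds measured so far in a functional assay on cells (Cancer cell lines, Homo sapiens) for cytotoxicity, read by sulforhodamine B assay, with a stated time of 48 h (on this read-out higher numbers stand for weaker inhibition of growth and lower numbers for stronger inhibition of growth), standing at 36500 nM. Compound 2 `Oc1ccc(O)c(-c2cc(-c3ccc(Cl)cc3)nn2-c2ccccc2)c1` gives 14600 nM in this assay, and the step from compound 2 to compound 3 read a 2.5-fold higher number from compound 2 to compound 3 (0.40 log units; beyond the scatter). Compound 1 `COc1ccc(OC)c(-c2cc(-c3ccccc3)nn2-c2ccc(S(=O)(=O)NC(C)=O)cc2)c1` gives 12000 nM. Compound 4 `NS(=O)(=O)c1ccc(-n2nc(-c3ccc(Cl)cc3)cc2C2=CC(=O)C=CC2=O)cc1` differs from compound 3 in one place: sulfamoyl in place of hydrogen on an aromatic carbon, the sulfamoyl entering on an aromatic carbon of a six-membered aromatic ring of carbon only, para to a large group. Within the data shown here, none of the measured steps covers this change, and compound 1 differs from compound 3 in several places at once, so no single-change comparison exists. The step is therefore expected to stay within the scatter, a 1.3-fold lower number from compound 3 to compound 4 (0.12 log units; within the scatter), with a wide range. Compound 4 is estimated at 28000 nM, between 8000 nM and 90000 nM.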

Compound 4, concentration for 50% growth inhibition: 21600 nM
The estimate for compound 4 lay 1.3-fold (0.11 log units) above the measured number; low and high end bracket the measured number.
By their numbers in this assay, from the lowest: compounds 1, 2, 4 and 3 (each within the scatter of the next, the first and the last beyond it).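

In this assay, within the data shown here, the change from phenyl to 4-sulfamoylphenyl gives a 1.7-fold lower number from compound 3 to compound 4 (0.23 log units; within the scatter) and is the first single change read on this aromatic carbon. On compound 3, this position therefore takes sulfamoyl without a shift beyond the scatter. Nothing available explains this outcome. As far as these compounds go, whether a carboxylic acid or an amine on this same carbon would leave the number as little changed remains open. So does whether sulfamoyl would behave the same way on compound 2 .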